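Nitro in Place of Chloro on a Shared Core

The source may hold more compounds than are shown below. What is called first, only, known or untested is meant among the compounds shown, and "the series" means these compounds.

Of the compounds shown here, three built on one core have been tested in an assay on isolated protein for inhibition of complement C1r subcomponent (Homo sapiens); a lower number here means a stronger inhibitor, a higher number a weaker inhibitor. Compound 1 `O=c1oc(-c2ccccc2I)nc2cc(Cl)ccc12` gives > 62500 nM, which is a limit of the assay rather than a number. Compound 2 `O=c1oc(-c2ccccc2I)nc2cc(Cl)c(Cl)cc12` gives > 62500 nM, again a limit. Compound 3 `COc1ccc2nc(-c3ccccc3I)oc(=O)c2c1` likewise gives > 62500 nM, a limit. Compound 1 therefore stands at the same limit as the other two, and no order among them can be read. Going by the values given here, the one change in a single place among measured compounds, chloro in place of hydrogen on an aromatic carbon, is a step that the two limits leave unreadable from compound 1 to compound 2. The whole of the evidence is the limit of > 62500 nM in this assay, at which 3 of the 3 values shown sit.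

Compound 4 `O=c1oc(-c2ccccc2I)nc2cc([N+](=O)[O-])ccc12` has not yet been measured. It differs from compound 1 in one place: nitro in place of chloro on an aromatic carbon. Among the compounds with values here, no measured step bears on this change, and the only step between measured compounds is unreadable because both of its ends sit at the limit of > 62500 nM in this assay, at which 3 of the 3 values shown sit. The expected step is therefore a step that the limit leaves unreadable from compound 1 to compound 4, with no movement beyond the scatter foreseen. Compound 4 is estimated at 100000 nM, with a range from 30000 nM to 500000 nM, and it will most likely also return only a limit.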

Compound 4, half-maximal inhibitory concentration: > 62500 nM
Compound 4: a limit, no number (the forecaster's own chance of this, stated with the estimate: 85%); the middle value is on the limit's open side.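

Going by these compounds alone, compound 1 and compound 4 each return only a limit of the assay, so no step from one to the other can be read. The compounds shown leave open whether any change on the shared core would give an actual number in this assay.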